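Lengthening the Alkene Chain from Compound 2 to Compound 3

The source may report more compounds than this note shows. Statements on the series, on what has been measured and on what is new or still open speak of the compounds shown alone.

Measured so far in a functional assay on L929 cells (Mus musculus) for antiproliferative activity, read by MTT assay; a higher number here means a weaker inhibitor, a lower number a stronger inhibitor:
- compound 1 `C[C@@H]1[C@H]2CC(=O)[C@H](C)[C@H]2C[C@H]1O[Si](c1ccccc1)(c1ccccc1)C(C)(C)C`: 7400 nM
- compound 2 `C=CC[C@H]1C(=O)C[C@@H]2[C@@H](C)[C@H](O[Si](c3ccccc3)(c3ccccc3)C(C)(C)C)C[C@@H]21`: 17800 nM

Of these two, compound 2 has the higher number, which makes it the weaker inhibitor. The next compound, compound 3 `CC(C)=CC[C@H]1C(=O)C[C@@H]2[C@@H](C)[C@H](O[Si](c3ccccc3)(c3ccccc3)C(C)(C)C)C[C@@H]21`, keeps the shared core and changes one group: 2-methylprop-1-en-1-yl in place of vinyl on a saturated chain carbon bound to a saturated ring carbon. Put simply, 2-methylprop-1-en-1-yl stands in place of vinyl on a saturated chain carbon bound to a saturated ring carbon, which turns allyl into 3-methylbut-2-en-1-yl.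

Within the data shown here, only one measured step bears on this change. Adding the vinyl gave a 2.4-fold higher number from compound 1 to compound 2 (0.38 log units; beyond the scatter), a modest loss. One step is thin evidence, so in this assay a step of similar or smaller size is expected, leaning towards a higher number and possibly none beyond the scatter. The expected change is a 1.3-fold higher number from compound 2 to compound 3 (0.13 log units; within the scatter). The estimate for compound 3 is 24000 nM, with an expected range from 9000 nM to 55000 nM.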

Compound 3, half-maximal inhibitory concentration: 23900 nM
The estimate for compound 3 lay 1.0-fold (0.00 log units) above the measured number, and the stated range covers the measured number.
By their numbers in this assay, from the lowest: compound 1; then compounds 2 and 3 (each within the scatter of the next).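

In this assay, replacing vinyl with 2-methylprop-1-en-1-yl, which turns allyl into 3-methylbut-2-en-1-yl, gives a 1.3-fold higher number from compound 2 to compound 3 (0.13 log units; within the scatter), so this larger alkene chain is tolerated about as well as the smaller one. Set against hydrogen at the same place, the larger group gives a 3.2-fold higher number from compound 1 to compound 3 (0.51 log units; beyond the scatter), which confirms that a second alkene chain here also comes with a modest loss rather than a gain. Nothing measured on these compounds offers a reason for these numbers.

From the compounds shown here alone, both chains on this carbon are hydrocarbon alkenes, so it remains open how a saturated propyl chain, an amine or a carboxylic acid would behave at this place. Going by these compounds, it is also open whether any group here could bring the number below that of compound 1, which carries only hydrogen.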